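Propargyl in Place of Benzyl on the Amide of Compound 3

The source may report more compounds than this note shows. Statements on the series, on what has been measured and on what is new or still open speak of the compounds shown alone.

Compound 1 `CCN(CC)C(=O)c1nc2ccccc2n1Cc1ccccc1`: > 10000 nM, a limit of the assay
Compound 2 `CCN(CC)C(=O)c1nc2ccccc2n1Cc1ccc(OC)nc1`: > 10000 nM, a limit of the assay
Compound 3 `CN(Cc1ccccc1)C(=O)c1nc2ccccc2n1Cc1ccc(Cl)cc1`: > 10000 nM, a limit of the assay

In an assay on membranes from HEK293 cells for displacement of a labelled ligand from Translocator protein (Homo sapiens), read by scintillation counting, with a stated time of 90 min (on this read-out higher numbers stand for weaker inhibition and lower numbers for stronger inhibition), compound 3 gives only a limit and not a number. Compound 1 and compound 2 likewise give limits, so all three sit at the limit of > 10000 nM in this assay, at which 3 of the 3 values shown sit. Among the measured compounds shown here, the one step between measured compounds, a step that the two limits leave unreadable from compound 1 to compound 2, runs between two limits and its size cannot be read. Compound 4 `C#CCN(C)C(=O)c1nc2ccccc2n1Cc1ccc(Cl)cc1` differs from compound 3 by ethynyl in place of phenyl on a saturated chain carbon bound to an amide-type nitrogen. For the measured compounds named here, no measured step bears on this change, and compound 3 itself is only a limit, so no step of readable size is expected in this assay. Compound 4 is expected at 20000 nM, between 4000 nM and 100000 nM. The step that the limit leaves unreadable from compound 3 to compound 4 that this estimate means is expected to remain unreadable against the limit.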

Compound 4, inhibition constant: > 10000 nM
Compound 4: no number, only a limit (the forecaster's own chance of this, stated with the estimate: 85%); the middle value is on the limit's open side.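

Compound 3 and compound 4 each give only a limit, so the step between them cannot be read: the limit of > 10000 nM in this assay, at which 4 of the 4 values shown sit.

The compounds shown leave open what change to the shared core, if any, would give a readable number in this assay.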